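This account rests on a few compounds, and the source may have more. Where it says the series, first, only, none or still open, it means among the compounds named here.

Of the compounds shown here, two that share one core have been measured so far in a functional assay on MCF7 cells (Homo sapiens) for inhibition, read by MTT assay, with a stated time of 24 h; on this read-out higher numbers stand for weaker inhibition of growth and lower numbers for stronger inhibition of growth. In this assay, compound 1 `COc1ccc2c(c1)c(-c1nc3ccccc3n1C(=O)c1ccccc1Br)cn2C` gives 55800 nM and compound 2 `COc1ccc2c(c1)c(-c1nc3ccccc3n1C(=O)c1cccc(Br)c1)cn2C` gives 52700 nM. These numbers lie within the usual scatter of each other, so compound 2 stands level with compound 1 and the two cannot be ranked.

The next compound, compound 3 `Cn1cc(-c2nc3ccccc3n2C(=O)c2cccc(Br)c2)c2cc(Br)ccc21`, keeps the 3-bromophenyl on the carbonyl carbon of compound 2 and differs elsewhere: bromo in place of methoxy on an aromatic carbon. In short, it carries bromo in place of methoxy on an aromatic carbon.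

Among the compounds with values here, the only measured step is a 1.1-fold lower number from compound 1 to compound 2 (0.02 log units; within the scatter). It swaps 3-bromophenyl for 2-bromophenyl, a change at a different place, so it bears on the new change only indirectly. Within the data shown here, no measured pair yet shows what replacing methoxy does here, and the data favour neither direction. The expectation in this assay is therefore no change beyond the scatter, with an estimated 1.1-fold lower number from compound 2 to compound 3 (0.02 log units; within the scatter). Compound 3 is estimated at 50000 nM, with an expected range from 20000 nM to 110000 nM.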

Compound 3, concentration for 50% growth inhibition: 68200 nM
Estimate against measurement, compound 3: 1.4-fold (0.13 log units) below; low and high end bracket the measured number.
By their numbers in this assay, from the lowest: compounds 2, 1 and 3 (each within the scatter of the next).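

Within the data shown here, the change at this aromatic carbon is the first made away from the bromophenyl on the carbonyl carbon, and in this assay bromo in place of methoxy gives a 1.3-fold higher number from compound 2 to compound 3 (0.11 log units; within the scatter) and so cannot be told apart from no effect. This position therefore accepts a swap of methoxy, with its oxygen and its hydrogen-bond acceptor, for bromo, which has neither, without a difference that stands out from the scatter, so that acceptor is not shown to matter on this read-out. Nothing measured on these compounds offers any explanation for this outcome.

Among these compounds, whether a group of a different kind on this aromatic carbon, such as an amine or a carboxylic acid, would move the number beyond the scatter remains open, since methoxy and bromo are the only two groups seen there so far. Among the compounds shown here, it is also open whether the same swap would read alike with 2-bromophenyl on the carbonyl carbon, as the only pair showing this change carries 3-bromophenyl.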